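Hydroxypyrazole amide in place of hydroxyoxadiazole, both partners inactive

The compounds below may be only part of what the source reports. "The series", "measured", "known", "first", "only" and "open" are said of these compounds alone.

Compound 2 `O=C(Nc1cc(C(F)(F)F)cc(C(F)(F)F)c1)c1nonc1O` is the starting point. In an assay on isolated protein for inhibition of mitogen-activated protein kinase kinase kinase 14 (Homo sapiens), read by ADP-Glo, with a stated time of 60 min, in the presence of a further agent that is not named here (a higher number here means a weaker inhibitor, a lower number a stronger inhibitor), compound 2 reports only a limit, > 100000 nM. Compound 1 `O=C(Nc1cc(C(F)(F)F)cc(C(F)(F)F)c1)c1n[nH]nc1O` likewise gives a limit in this assay, > 100000 nM. The step that the two limits leave unreadable from compound 1 to compound 2 therefore cannot be sized, because of the limit of > 100000 nM in this assay, at which 2 of the 2 values shown sit. Compound 3 `Cc1c(C(=O)Nc2cc(C(F)(F)F)cc(C(F)(F)F)c2)c(O)nn1C` differs from compound 2 by 3-hydroxy-1,5-dimethyl-1H-pyrazol-4-yl in place of 4-hydroxy-1,2,5-oxadiazol-3-yl on a carbonyl carbon. Within the data shown here, no measured step bears on this change, and both known values sit at the limit. Compound 3 is therefore expected to remain weak, with an estimated step that the limit leaves unreadable from compound 2 to compound 3. The estimate for compound 3 is 150000 nM, within 30000 nM to 1000000 nM.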

Compound 3, half-maximal inhibitory concentration: > 100000 nM
Compound 3: a limit, no number; the forecaster's own chance of this, stated with the estimate: 85%; the middle value does not contradict the limit.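

Among these compounds, no step among compound 1, compound 2 and compound 3 can be read, because all three rest on the same limit: the limit of > 100000 nM in this assay, at which 3 of the 3 values shown sit. Which group on the carbonyl carbon, if any, would give a measurable value in this assay stays open.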